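Two Analogues and an Untested Combination

A few compounds are considered here, and "the series" means these few. Any claim that something is new, unique, unknown or untested is made for them only; others in the source may bear on it.

Measured compounds:
Compound 1, `CC(C)(C)Cc1csc(N)c1C(=O)c1cccc(C(F)(F)F)c1`, in an assay on CHO cells for displacement of a labelled ligand from adenosine receptor A3 (Homo sapiens), read by scintillation counting, tested at 10 uM; a higher number here means more inhibition at the concentration tested (going by the name of the read-out), a lower number less inhibition: 1%
Compound 2, `CC(C)(C)Cc1c(Br)sc(N)c1C(=O)c1cccc(Cl)c1`, in this assay: 1%

Going by the values given here, compound 1 and compound 2 share a common core and differ in two places at once, so no single step connects them. In this assay compound 2 gives 1%, which stands level with compound 1 at the digits shown; the two are within the scatter of each other, and neither number can be called the higher or the lower.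

Compound 3, `CC(C)(C)Cc1c(Br)sc(N)c1C(=O)c1cccc(C(F)(F)F)c1`, has not been measured yet. It is reached from compound 2 by one change: trifluoromethyl in place of chloro on an aromatic carbon. In effect, compound 3 carries the trifluoromethyl of compound 1 together with the bromo of compound 2.

Among the compounds with values here, since both measured compounds sit at essentially no inhibition in this assay, and the only change is the one described, the step from compound 2 to compound 3 is expected to be a number 1 percentage points higher from compound 2 to compound 3 (within the scatter), that is, no step beyond the scatter in either direction. Compound 3 is therefore estimated at 2%, with a range from -8% to 12%.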

Compound 3, a percentage reported as inhibition, at one concentration (the size of the read-out at that concentration, not a potency): 4%
For compound 3 the middle estimate is 2 percentage points below the measured one; measured number inside the range.
By their numbers in this assay, from the lowest: compounds 1, 2 and 3 (each within the scatter of the next).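

In this assay, trifluoromethyl in place of chloro on an aromatic carbon, meta to a large group, gives a number 3 percentage points higher from compound 2 to compound 3 (within the scatter), so with the bromo present, this exchange of groups makes no difference beyond the usual scatter. Going by these compounds alone, compound 3 also lets each of the two differences between the earlier compounds be read on its own, and bromo in place of hydrogen on an aromatic carbon gives a number 3 percentage points higher from compound 1 to compound 3 (within the scatter), which again lies within the scatter. No separate evidence bears on these results.

The compounds shown leave open whether an amine or a carboxylic acid on this aromatic carbon would give a reading beyond the scatter, since chloro and trifluoromethyl are the only two groups compared there. Within the data shown here, with only one pair showing the exchange of chloro for trifluoromethyl, it also remains open whether the same result would hold on the core with hydrogen in place of the bromo, or with a longer chain in place of the one shared by these compounds.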